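The source may hold more compounds than are shown below. What is called first, only, known or untested is meant among the compounds shown, and "the series" means these compounds.

The compounds measured in an in vitro functional assay on HEK285-7 cells for antagonist activity at prostaglandin D2 receptor 2 (Homo sapiens), read by BRET and beta-arrestin recruitment (a higher number here means a larger maximal response, a lower number a smaller maximal response), are:

Compound 1 `CCC(c1ccccc1)c1nc(-c2ccc(Cl)cc2)c(CC(=O)O)s1`: 50%
Compound 2 `NS(=O)(=O)c1cccc(-c2nc(C(c3ccc(F)cc3)c3ccc(F)cc3)sc2CC(=O)O)c1`: 55%
Compound 3 `O=C(O)Cc1sc(C(c2ccccc2)c2ccccc2)nc1-c1cccc(F)c1`: 80%

Among these three numbers compound 2 stands second highest. Its nearest neighbour is compound 1, whose number lies within the scatter of that of compound 2, so no order between compound 1 and compound 2 can be read from this assay. Compound 3 is furthest away, with a higher number, a gap that lies beyond the scatter.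

Compound 4 `Nc1cc(-c2nc(C(c3ccc(F)cc3)c3ccc(F)cc3)sc2CC(=O)O)cc(F)n1` has not yet been measured. It differs from compound 2 in one place: 2-amino-6-fluoropyridin-4-yl in place of 3-sulfamoylphenyl on an aromatic carbon

For the measured compounds named here, no step between two measured compounds that differ in a single place is available, so the effect of this change cannot be read from the numbers in hand. The three measured compounds span a moderate range, and compound 2 sits in the middle of it. The expectation is that the step of a number 5 percentage points higher from compound 2 to compound 4 (within the scatter) remains small, without a clear direction, and does not exceed the scatter. Compound 4 is therefore expected to reach about 60% in this assay, with a range from 40% to 85%.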

Compound 4, largest response reached (reported as efficacy), in percent of the reference or control that the assay uses: 30%
Estimate against measurement, compound 4: 30 percentage points above; the whole stated range lies above it.
By their numbers in this assay, from the lowest: compound 4; then compounds 1 and 2 (each within the scatter of the next); then compound 3.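

In this assay, for the compounds shown here, putting 2-amino-6-fluoropyridin-4-yl in place of 3-sulfamoylphenyl, on the aromatic carbon next to the ring nitrogen and next to the ring atom that bears the carboxymethyl group, gives a number 25 percentage points lower from compound 2 to compound 4 (beyond the scatter) and is the only single-place step in hand, so it shows that the maximal response at this assay depends on the group held at this position. The change also shows that matching counts do not keep the number in place: both groups have 1 hydrogen-bond donor and 2 hydrogen-bond acceptors, and both carry no net charge. Nothing available explains why this swap lowers the number.

The amino group, the fluorine and the ring nitrogen enter together, so the compounds shown leave open which of them goes with the lower number, a question that 2-aminopyridin-4-yl or plain pyridin-4-yl at this position would address. As far as these compounds go, it also remains open whether the same swap would give a similar step when the large group on the core is something other than the two 4-fluorophenyl rings of compound 2 and compound 4.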